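The source may hold more compounds than are shown below. What is called first, only, known or untested is meant among the compounds shown, and "the series" means these compounds.

Measured so far in an assay on microsomes for inhibition of acyl-CoA:cholesterol acyltransferase (Oryctolagus cuniculus); a higher number here means a weaker inhibitor, a lower number a stronger inhibitor:
compound 1, `CC(C)c1cccc(C(C)C)c1NC(=O)NCC1(c2cccc(CO)c2)CCCC1`: 15 nM
compound 2, `CC(C)c1cccc(C(C)C)c1NC(=O)NCC1(c2ccc(CO)cc2)CCCC1`: 26 nM

Among the measured compounds shown here, compound 2 stands alongside compound 1 in this assay, the two numbers lying within the scatter of each other: the only step known, a 1.7-fold higher number from compound 1 to compound 2 (0.24 log units; within the scatter), is small and shows that moving the hydroxymethyl group around the aromatic ring on the saturated ring carbon leaves the half-maximal inhibitory concentration essentially unchanged.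

Compound 3, `Cc1ccc(C2(CNC(=O)Nc3c(C(C)C)cccc3C(C)C)CCCC2)c(C)c1`, has not yet been measured in this assay. It differs from compound 2 by 2,4-dimethylphenyl in place of 4-(hydroxymethyl)phenyl on a saturated ring carbon. For the measured compounds named here, no measured step bears directly on this exchange; the single step available, from compound 1 to compound 2, concerns only the placement of the hydroxymethyl group and not its removal, and there is no compound in the set without a hydrogen-bond donor or acceptor on that ring. The expectation for compound 3 therefore rests on the shared core alone, with a wide range. Compound 3 is expected to give 22 nM, between 6 nM and 90 nM, which means an estimated step of a 1.2-fold lower number from compound 2 to compound 3 (0.07 log units; within the scatter) that is not expected to reach beyond the scatter.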

Compound 3, half-maximal inhibitory concentration: 50 nM
Beside the measured number, compound 3's estimate is 2.3-fold (0.36 log units) below it; the range from low to high includes it.
By their numbers in this assay, from the lowest: compounds 1, 2 and 3 (each within the scatter of the next, the first and the last beyond it).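

Among the compounds shown here, this is the first exchange at this position that removes the hydroxymethyl group altogether. With 2,4-dimethylphenyl, which has 0 hydrogen-bond donors and 0 hydrogen-bond acceptors, on the saturated ring carbon, this assay gives a 1.9-fold higher number from compound 2 to compound 3 (0.28 log units; within the scatter) and a 3.3-fold higher number from compound 1 to compound 3 (0.52 log units; beyond the scatter), so compound 3 stays within the scatter of one hydroxymethyl compound and lies only modestly beyond that of the other, which shows that a hydroxymethyl group is not required on this ring for inhibition at this level among the three compounds. Nothing measured here accounts for the gap between the two steps, or for either step on its own.

The compounds shown leave open how much of these steps belongs to the loss of the hydroxymethyl group and how much to the arrival of the methyl groups, as the exchange changes both at once. Also open, going by these compounds, is how a plain phenyl, or a phenyl carrying an amine or a carboxylic acid, would stand in this assay on the same saturated ring carbon.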